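From methoxymethyl to ethynyl on a carbonyl carbon

This account rests on a few compounds, and the source may have more. Where it says the series, first, only, none or still open, it means among the compounds named here.

Of the compounds shown here, two have so far been measured in a functional assay on KYSE-450 cells (Homo sapiens) for inhibition, read by MTT assay, with a stated time of 48 h (on this read-out lower numbers stand for stronger inhibition and higher numbers for weaker inhibition), and their numbers lie far apart. Compound 1 (`COCC(=O)N(Cc1ccc(OC)c(O)c1)c1cc(OC)c(OC)c(OC)c1`) gives 460 nM in this test, the lower of the two numbers. Compound 2 (`COc1ccc(CNc2cc(OC)c(OC)c(OC)c2)cc1Cl`) gives 47800 nM in the same test, a gap to compound 1 that lies beyond the usual scatter.

The compound still to be measured, compound 3 (`C#CC(=O)N(Cc1ccc(OC)c(O)c1)c1cc(OC)c(OC)c(OC)c1`), keeps the core of compound 1 and carries ethynyl in place of methoxymethyl on a carbonyl carbon. Among the measured compounds shown here, no measured pair shows this change, so the expectation rests on compound 1 alone, with its 460 nM as the starting point. An estimated 1.7-fold higher number from compound 1 to compound 3 (0.24 log units; within the scatter) is expected in this assay as a slight move toward weaker inhibition that does not go beyond the scatter. For compound 3 the estimated value is 800 nM with an expected range from 150 nM to 4000 nM on this read-out, a wide span that reflects the single close comparator.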

Compound 3, half-maximal inhibitory concentration: 570 nM
Compound 3: the middle estimate sits 1.4-fold (0.15 log units) above what was measured; the range from low to high includes it.
By their numbers in this assay, from the lowest: compounds 1 and 3 (each within the scatter of the next); then compound 2.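

In this assay, putting ethynyl in place of methoxymethyl on a carbonyl carbon gives a 1.2-fold higher number from compound 1 to compound 3 (0.09 log units; within the scatter), so compound 1 and compound 3 cannot be told apart on this read-out. Among the compounds shown here, this is the first comparison that isolates a single place, and it shows that, on a carbonyl carbon whose other neighbours are an amide-type nitrogen, this exchange leaves the number within the scatter even though the hydrogen-bond acceptor of methoxymethyl leaves and a triple bond enters. No supporting measurement is available to explain why these two groups read alike.

From the compounds shown here alone, whether this tolerance extends to other groups on the same carbonyl carbon remains open, since a single exchange cannot show how an amine, a carboxylic acid or a longer alkyl chain would read there. Compound 2 differs from compound 1 and compound 3 in more than one place, so the compounds shown also leave open how much the substituted carbonyl itself contributes to the number in this assay.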